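A Saturated Ring Replaces a Chlorinated Aromatic One

This account rests on a few compounds, and the source may have more. Where it says the series, first, only, none or still open, it means among the compounds named here.

Of the compounds shown here, three have been measured in an in vitro functional assay on cells for agonist activity at Bombesin receptor subtype-3 (Homo sapiens), read by luminescence and calcium flux; a lower number here means that less compound is needed, a higher number that more compound is needed for the effect. Compound 1 `CCCCc1cnc(C(Cc2ccc(-c3ccccc3C(=O)O)cc2)C(C)C)[nH]1` gives 4620 nM, compound 3 `CCCCc1cnc(C(CCCO)Cc2ccc(-c3ccccc3C(=O)O)cc2)[nH]1` gives 1900 nM, and compound 2 `O=C(O)c1ccccc1-c1ccc(CCc2ncc(Cc3ccccc3Cl)[nH]2)cc1` gives 292 nM. Among the measured compounds shown here, the only single-point change among them, a 2.4-fold lower number from compound 1 to compound 3 (0.39 log units; beyond the scatter), shows how much one substituent swap on the chain can move the number. Compound 2 holds the lowest number of the three, so the least compound is needed for the effect there.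

Compound 4 `O=C(O)c1ccccc1-c1ccc(CCc2ncc(CC3CCCCCC3)[nH]2)cc1` differs from compound 2 in one place: cycloheptyl in place of 2-chlorophenyl on a saturated chain carbon bound to an aromatic carbon. For the measured compounds named here, no measured step covers an exchange of an aromatic ring for a saturated one, so the size of this step is uncertain. Because the step of a 2.4-fold lower number from compound 1 to compound 3 (0.39 log units; beyond the scatter) was modest, a comparable magnitude seems plausible, and with a ring of carbon only in place of a ring carrying chlorine, a somewhat higher number is expected. The expected step is a 2.4-fold higher number from compound 2 to compound 4 (0.38 log units; beyond the scatter). Compound 4 is estimated at 700 nM, between 180 nM and 2800 nM.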

Compound 4, half-maximal effective concentration: 88 nM
Compound 4: the middle estimate sits 8.0-fold (0.90 log units) above what was measured, outside the stated range (below it).
By their numbers in this assay, from the lowest: compound 4; then compound 2; then compound 3; then compound 1.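

In this assay, moving from 2-chlorophenyl to cycloheptyl gives a 3.3-fold lower number from compound 2 to compound 4 (0.52 log units; beyond the scatter). This place, on a saturated chain carbon bound to an aromatic carbon, therefore tolerates a seven-membered non-aromatic ring of carbon only, and in this pair neither an aromatic ring nor a chlorine is needed for the lower number. No measurement at hand explains why the saturated ring gives that lower number.

The swap changes the ring and removes the chlorine in a single move, and the compounds shown do not tell these two changes apart. From the compounds shown here alone, a plain phenyl or a cyclohexyl here would help separate them, and whether cycloheptyl gives a similar step on the core of compound 3 also stays open.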